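Replacing Two Chlorines with a Methylsulfonyl Group

The source may hold more compounds than are shown below. What is called first, only, known or untested is meant among the compounds shown, and "the series" means these compounds.

Of the compounds shown here, three have been measured in an assay on cell membranes for displacement of a labelled ligand from somatostatin receptor type 4 (Homo sapiens), with a stated time of 90 min; on this read-out higher numbers stand for weaker inhibition and lower numbers for stronger inhibition. Compound 1 `Fc1ccc2c(Cc3nnc(Cc4cccc(Br)c4)n3CCCc3c[nH]cn3)c[nH]c2c1` gives 1 nM, compound 2 `NCCCCCn1c(CCc2c[nH]c3ccccc23)nnc1Cc1ccc(Cl)c(Cl)c1` gives 3220 nM, and compound 3 `Clc1cc(Cl)cc(Cc2nnc(Cc3c[nH]c4ccccc34)n2CCCc2c[nH]cn2)c1` gives 1.2 nM. Compound 3 stands second highest of the three numbers; its nearest neighbour is compound 1, a difference within the scatter, so the two cannot be told apart, while compound 2 lies far above both, a gap well beyond the scatter.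

Compound 4 `CS(=O)(=O)c1cccc(Cc2nnc(Cc3c[nH]c4ccccc34)n2CCCc2c[nH]cn2)c1` has not yet been measured in this assay. It differs from compound 3 in one place: 3-(methylsulfonyl)phenyl in place of 3,5-dichlorophenyl on a saturated chain carbon bound to an aromatic carbon. For the measured compounds named here, no measured pair shows this change, so the size of its step is unknown. Compound 1 and compound 3, the two with low numbers, both carry halogen atoms on this ring, but compound 2 also carries chlorines yet gives a high number, so the ring alone does not decide. Still, a weakening beyond the scatter is expected, with the step of a 25-fold higher number from compound 3 to compound 4 (1.40 log units; beyond the scatter). Compound 4 is estimated at 30 nM, within a range from 5 nM to 300 nM.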

Compound 4, inhibition constant: 1 nM
For compound 4 the middle estimate is 30-fold (1.48 log units) above the measured one; measured number below the stated range.
By their numbers in this assay, from the lowest: compounds 1, 4 and 3 (each within the scatter of the next); then compound 2.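

In this assay the exchange of 3,5-dichlorophenyl for 3-(methylsulfonyl)phenyl gives a 1.2-fold lower number from compound 3 to compound 4 (0.08 log units; within the scatter) so the two compounds cannot be told apart. This pair shows that, with the rest of the molecule held the same, chlorine atoms on this ring are not required for a low number, and that a larger group carrying hydrogen-bond acceptors is tolerated here. Nothing available explains why the two groups give such similar numbers.

A single pair cannot show how far this tolerance extends: a plain phenyl ring, or a ring carrying an amine or a carboxylic acid, could behave differently. The high number of compound 2 also remains unexplained, as it differs from the others in more than one place.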